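From 4-methoxyphenyl to 4-cyanophenyl

The source may hold more compounds than are shown below. What is called first, only, known or untested is meant among the compounds shown, and "the series" means these compounds.

For the measured compounds named here, in an ADME assay on NIH3T3 cells (Mus musculus) for inhibition, read by MTT assay, with a stated time of 48 h (a lower number here means a stronger inhibitor, a higher number a weaker inhibitor), compound 1 (`COc1ccc(-c2nc3ccccn3c2Sc2ccccc2)cc1`) gives 91700 nM as the only actual number so far. Compound 2 (`c1ccc(Sc2c(-c3cccc4ccccc34)nc3ccccn23)cc1`) is reported as > 100000 nM which is a limit and not a number. Compound 3 (`N#Cc1ccc(-c2nc3ccccn3c2Sc2ccccc2)cc1`) keeps the core of compound 1 but has cyano in place of methoxy on an aromatic carbon, para to a large group (cyano in place of methoxy on an aromatic carbon). Going by the values given here, no measured pair shows this change, so no step beyond the scatter is expected in this assay in either direction. The estimated step of a 1.2-fold lower number from compound 1 to compound 3 (0.09 log units; within the scatter) stays within that scatter. Compound 3 is expected at about 75000 nM with an estimated range from 35000 nM to 100000 nM for this compound.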

Compound 3, half-maximal inhibitory concentration: > 100000 nM
Compound 3: a limit, no number; the forecaster's own chance of this, stated with the estimate: 35%; middle value at least 1.3-fold (0.12 log units) from the limit.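

In this assay, cyano in place of methoxy on this aromatic carbon, para to a large group, gives a step that can only be stated as a floor: an at least 1.0-fold higher number from compound 1 to compound 3 (0.03 log units; that floor lies within the scatter). The change therefore brings no measurable number for compound 3, only a limit. The true size of the step cannot be read, because the result sits at the limit of the assay: the limit of > 100000 nM in this assay, at which 2 of the 3 values shown sit.

On these data alone, whether cyano and methoxy truly differ here beyond the scatter remains open. So does what an amine or a carboxylic acid would give on this carbon.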